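Nitrothiazole amides: furan substituent swapped, cytotoxicity pending

The source may report more compounds than this note shows. Statements on the series, on what has been measured and on what is new or still open speak of the compounds shown alone.

Three compounds in this series have a reading so far. In an ADME assay on HEK-293T cells (Homo sapiens) for cytotoxicity, read by MTT assay, tested at 25 uM (on this read-out higher numbers stand for a weaker effect at the one concentration tested and lower numbers for a stronger effect), compound 1 `CC(=O)Oc1c(Cl)cc(Cl)cc1C(=O)Nc1ncc([N+](=O)[O-])s1` gives 100%. In this assay compound 2 `CC(=O)Oc1c(C(=O)Nc2ncc([N+](=O)[O-])s2)cc(C(C)C)cc1C(C)C` gives 45.9%. Compound 3 `O=C(Nc1ncc([N+](=O)[O-])s1)c1ccc([N+](=O)[O-])o1` gives 87.4% in this assay, which puts it second highest of the three numbers: compound 1 sits higher by a margin beyond the scatter, and compound 2 sits lower by a margin beyond the scatter. Among the measured compounds shown here, no pair among the measured compounds differs in only one place, so no single step has been measured.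

Compound 4 `O=C(Nc1ncc([N+](=O)[O-])s1)c1ccc(-c2ccc(Br)cc2)o1` differs from compound 3 in one place: 4-bromophenyl in place of nitro on an aromatic carbon. The change sits on the five-membered ring carrying one oxygen, next to the ring oxygen. For the measured compounds named here, no measured step covers this kind of change, so the expectation rests only on the spread of the three numbers seen. A modest move toward a stronger effect is expected, with the step from a number 12.4 percentage points lower from compound 3 to compound 4 (beyond the scatter) taken as the working guess. Compound 4 is estimated at 75%, within a range from 45% to 100%.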

Compound 4, a percentage reported as activity, at one concentration (the size of the read-out at that concentration, not a potency): 89.1%
Compound 4: middle estimate off by 14.1 percentage points, on the low side, within the range that was stated.
By their numbers in this assay, from the lowest: compound 2; then compounds 3 and 4 (each within the scatter of the next); then compound 1.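

Working notes on the furan position: in this assay the first measured step at this position, 4-bromophenyl in place of nitro, is a number 1.7 percentage points higher from compound 3 to compound 4 (within the scatter) and so does not separate the two compounds. On this carbon, next to the ring oxygen, a group of 7 heavy atoms with a six-membered aromatic ring of carbon only and no hydrogen-bond acceptors therefore reads the same, within the scatter, as nitro with its 3 heavy atoms and hydrogen-bond acceptors. No measurement at hand bears on why these two groups read alike.

From the compounds shown here alone, whether an amine, a carboxylic acid or a longer alkyl chain on this carbon would also stay within the scatter of compound 3 remains open. Going by these compounds, a plain phenyl without the bromine is also open, so this single step cannot say whether the bromine contributes to the reading of compound 4.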